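The compounds below may be only part of what the source reports. "The series", "measured", "known", "first", "only" and "open" are said of these compounds alone.

Compound 1 `COc1ccccc1OCC1SCCN1C(=O)CN` is the starting point of this step. For the measured compounds named here, in a functional assay on the whole organism for inhibition, with Cavia porcellus as the target (a lower number here means that less compound is needed, a higher number that more compound is needed for the effect), compound 1 gives 57 mg/kg, the highest of the three numbers measured so far. Compound 2 `CCOC(=O)CCC(=O)N1CCSC1COc1ccccc1OC` gives 24 mg/kg and compound 3 `CCOC(=O)CC(=O)N1CCS(=O)(=O)C1COc1ccccc1OC` gives 28 mg/kg, so both of them need less compound than compound 1 for the same effect.

Compound 4 `CCOC(=O)C(C)(C)C(=O)N1CCSC1COc1ccccc1OC` differs from compound 1 in one place: 1-(ethoxycarbonyl)-1-methylethyl in place of aminomethyl on a carbonyl carbon. Going by the values given here, the one measured step that bears on this is the change from compound 1 to compound 2, where an (ethoxycarbonyl)methyl group replaced the amino group on the saturated chain carbon bound to the carbonyl carbon; it gave a 2.4-fold lower number from compound 1 to compound 2 (0.38 log units; beyond the scatter). Compound 3, which also carries an ethyl ester on its chain, gives a number close to compound 2. The move to compound 4 likewise trades the amine for an ethyl-ester-bearing chain, so a drop of similar size in this assay is expected, though the larger entering group leaves the exact size uncertain. Compound 4 is therefore estimated at 28 mg/kg, with a range from 14 mg/kg to 56 mg/kg, meaning an expected step of a 2.0-fold lower number from compound 1 to compound 4 (0.31 log units; beyond the scatter).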

Compound 4, dose for half-maximal effect: 61 mg/kg
For compound 4 the middle estimate is 2.2-fold (0.34 log units) below the measured one, outside the stated range (above it).
By their numbers in this assay, from the lowest: compounds 2 and 3 (each within the scatter of the next); then compounds 1 and 4 (each within the scatter of the next).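

In this assay, 1-(ethoxycarbonyl)-1-methylethyl in place of aminomethyl on the carbonyl carbon gives a 1.1-fold higher number from compound 1 to compound 4 (0.03 log units; within the scatter) and so shows that an ethyl ester on this chain does not by itself lower the number. At the same place, 1-(ethoxycarbonyl)-1-methylethyl in place of 2-(ethoxycarbonyl)ethyl gives a 2.5-fold higher number from compound 2 to compound 4 (0.41 log units; beyond the scatter) and so shows that the build of the chain carrying the ester matters, not only the presence of the ester. No measurement at hand gives a reason for this difference.

The compounds shown leave open whether the methyl branching or the chain length separates compound 2 from compound 4. They also leave open how a carboxylic acid in place of the ethyl ester, or a longer unbranched chain, would behave at this position.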